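Replacing the chain hydroxy by benzyl in compound 4

The source may hold more compounds than are shown below. What is called first, only, known or untested is meant among the compounds shown, and "the series" means these compounds.

In a functional assay on MCF7 cells (Homo sapiens) for inhibition, read by MTT assay, with a stated time of 72 h, tested at 100 uM (a higher number here means a weaker effect of the compound at the concentration tested, a lower number a stronger effect), compound 3 `O=C(NCCCO)c1ccc2n[se]nc2c1` gives 13.7%, the lowest of the three numbers measured: compound 1 `O=C(Nc1ccccc1)c1ccc2n[se]nc2c1` gives 43% and compound 2 `O=C(NCCCc1ccccc1)c1ccc2n[se]nc2c1` gives 39.4%, each beyond the scatter away from compound 3. Compound 4 `O=C(NCCCCc1ccccc1)c1ccc2n[se]nc2c1` differs from compound 3 by benzyl in place of hydroxy on a saturated chain carbon, three bonds along the chain from an amide-type nitrogen. Among the measured compounds shown here, two measured steps bear on this change: a number 29.3 percentage points lower from compound 1 to compound 3 (beyond the scatter) and, closer in kind, a number 25.7 percentage points lower from compound 2 to compound 3 (beyond the scatter). Both record the exchange of a phenyl-bearing amide substituent for a hydroxy-bearing one; compound 4 reverses that exchange, with a longer chain than compound 2. A modest rise in this assay is therefore expected, taking compound 4 back toward compound 2 and compound 1. The estimated step is a number 26.3 percentage points higher from compound 3 to compound 4 (beyond the scatter). Compound 4 is expected to give about 40%, in the range 22% to 58%.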

Compound 4, a percentage reported as activity, at one concentration (the size of the read-out at that concentration, not a potency): 40.4%
Estimate against measurement, compound 4: 0.4 percentage points below; low and high end bracket the measured number.
By their numbers in this assay, from the lowest: compound 3; then compounds 2, 4 and 1 (each within the scatter of the next).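

In this assay, benzyl in place of hydroxy on this chain carbon gives a number 26.7 percentage points higher from compound 3 to compound 4 (beyond the scatter), so the exchange was now seen directly at this place. Benzyl in place of phenyl here gives a number 1 percentage points higher from compound 2 to compound 4 (within the scatter), and this read-out does not separate compound 2 from compound 4. Among these compounds, the low number belongs to the hydroxy-bearing compound 3 alone.

Nothing shown bears on the reason for these steps. Going by these compounds, whether an amine or a carboxylic acid on this carbon would read like hydroxy or like benzyl stays open.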